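Swapping the Benzamide Cap on a Quinolinyl Hydroxamate

The source may hold more compounds than are shown below. What is called first, only, known or untested is meant among the compounds shown, and "the series" means these compounds.

In a functional assay on NFF cells (Homo sapiens) for antiproliferative activity (a lower number here means a stronger inhibitor, a higher number a weaker inhibitor), compound 3 `CN(C)c1ccc(C(=O)N[C@@H](CCCCCC(=O)NO)C(=O)Nc2cccc3cccnc23)cc1` gives 570 nM, the lowest of the three numbers; compound 1 `O=C(CCCCC[C@H](NC(=O)c1ccc(C(F)(F)F)cc1)C(=O)NCc1ccccc1)NO` gives 1610 nM and compound 2 `CN(C)c1ccc(C(=O)N[C@@H](CCCCCC(=O)NO)C(=O)NC2(Cc3ccccc3)CCCC2)cc1` gives 3000 nM. Going by the values given here, the only single-change step measured is a 5.3-fold lower number from compound 2 to compound 3 (0.72 log units; beyond the scatter), which concerns the amide end rather than the benzamide cap. Compound 4 `O=C(CCCCC[C@H](NC(=O)c1ccc(C(F)(F)F)cc1)C(=O)Nc1cccc2cccnc12)NO` differs from compound 3 at that cap: trifluoromethyl in place of dimethylamino on an aromatic carbon. Among the compounds with values here, no measured step isolates this change: compound 1 carries trifluoromethyl and compound 2 dimethylamino, but they also differ at the amide nitrogen, so their gap cannot be assigned. Compound 4 is therefore expected to give about 500 nM, with a range of 200 nM to 1500 nM. The expected step is a 1.1-fold lower number from compound 3 to compound 4 (0.06 log units; within the scatter), not beyond the scatter.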

Compound 4, half-maximal inhibitory concentration: 696 nM
Compound 4: the middle estimate sits 1.4-fold (0.14 log units) below what was measured, and the stated range covers the measured number.
By their numbers in this assay, from the lowest: compounds 3 and 4 (each within the scatter of the next); then compounds 1 and 2 (each within the scatter of the next).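

In this assay, the benzamide cap now has its own single-change step: trifluoromethyl in place of dimethylamino on the aromatic carbon, with the quinolin-8-yl amide held fixed, gives (a 1.2-fold higher number from compound 3 to compound 4 (0.09 log units; within the scatter)), so the two caps cannot be told apart here. With the trifluoromethyl cap held fixed, quinolin-8-yl in place of benzyl gives (a 2.3-fold lower number from compound 1 to compound 4 (0.36 log units; beyond the scatter)), a second amide-end step alongside the earlier one with the dimethylamino cap. Nothing available explains either result.

On these data alone, whether the cap swap stays this small with a benzyl amide remains open. So does how a methoxy group or a carboxylic acid on that aromatic carbon would compare.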